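A Carbonyl Enters Where Activity Sits at the Limit

The compounds below may be only part of what the source reports. "The series", "measured", "known", "first", "only" and "open" are said of these compounds alone.

In a functional assay on A549 cells (Homo sapiens) for antiproliferative activity, read by MTT assay, with a stated time of 24 h (on this read-out higher numbers stand for weaker inhibition and lower numbers for stronger inhibition), three related compounds have been measured so far. Going by the values given here, compound 1 `Cc1ccccc1NNC(=O)c1cccc(NS(=O)(=O)c2cnc(O)nc2O)c1` gives 14200 nM, the only true number among them. Compound 2 `Cc1cccc(NNC(=O)c2ccccc2NS(=O)(=O)c2cnc(O)nc2O)c1` reaches only a limit of the assay, at > 20000 nM. Compound 3 `O=C(NNc1ccc(F)cc1)c1ccccc1NS(=O)(=O)c1cnc(O)nc1O` is also only a limit, at > 20000 nM. Compound 3 thus stands at the limit of > 20000 nM in this assay, at which 2 of the 3 values shown sit, so its real strength is not known.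

Compound 4 `O=C(NNC(=O)c1ccccc1NS(=O)(=O)c1cnc(O)nc1O)c1ccccc1F` differs from compound 3 in one place: (2-fluorophenyl)carbonyl in place of 4-fluorophenyl on an amine nitrogen. Here (2-fluorophenyl)carbonyl stands in place of 4-fluorophenyl on an amine nitrogen.

Among the compounds with values here, the one measured step that bears on this change is a step that the two limits leave unreadable from compound 2 to compound 3. It alters the group on the same amine nitrogen, but it gives no size to carry over. Within the data shown here, none of the measured compounds carries a carbonyl at this place either. A step beyond the usual scatter therefore cannot be expected in either direction, and in this assay the result may well be a limit again. The expected change is a number no higher from compound 3 to compound 4 (the limit leaves the size open). For compound 4 the estimated value is 20000 nM, with an expected range from 8000 nM to 50000 nM.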

Compound 4, half-maximal inhibitory concentration: 7150 nM
Beside the measured number, compound 4's estimate is 2.8-fold (0.45 log units) above it; the whole stated range lies above it.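

In this assay, a carbonyl-bearing group on this amine nitrogen brings compound 4 to a true number, where the groups seen earlier at this place left only limits. (2-Fluorophenyl)carbonyl in place of 4-fluorophenyl gives an at least 2.7-fold lower number from compound 3 to compound 4 (0.44 log units; beyond the scatter), and the same group in place of 3-methylphenyl gives an at least 2.7-fold lower number from compound 2 to compound 4 (0.44 log units; beyond the scatter), so this place can carry a change beyond the scatter and is not silent in this assay. The real size of both steps stays unknown, because each starts from a compound that gives only a limit: the limit of > 20000 nM in this assay, at which 2 of the 4 values shown sit.

The change also alters two things at once: a carbonyl enters, and the fluorine sits on a differently substituted ring, so the compounds shown cannot say how much of the gain belongs to either. From the compounds shown here alone, how a phenylcarbonyl without fluorine, a (4-fluorophenyl)carbonyl or a small acetyl group would read on this amine nitrogen stays open, and each of these would help to separate the part played by the carbonyl from the part played by the fluorine. Nothing measured here gives a reason for the gain itself.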